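Methoxy for trifluoromethyl on a thioether-linked aminoindane

The source may report more compounds than this note shows. Statements on the series, on what has been measured and on what is new or still open speak of the compounds shown alone.

Measured compounds in an ADME assay on isolated protein for inhibition of Amine oxidase [flavin-containing] B (Homo sapiens); on this read-out higher numbers stand for weaker inhibition and lower numbers for stronger inhibition:
Compound 1, `C#CCNC1CCc2c(SCCc3cccc(C(F)(F)F)c3)cccc21`, gives 280 nM.
Compound 2, `C#CCNC1CCc2c(SCc3ccc(F)cc3F)cccc21`, gives 1480 nM.
Compound 3, `C#CCNC1CCc2c(SCc3ccc(Cl)c(Cl)c3)cccc21`, gives 74 nM.

Three compounds share one core, a propargylamine on a bicyclic scaffold carrying a sulfur-linked aromatic side arm, and differ only in that side arm. Compound 1 stands second highest of the three numbers in this assay. Compound 3 sits below it, and compound 2 sits above it, and both of those gaps are beyond the usual scatter, so compound 1 is clearly separated from each of its neighbours.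

The next compound, compound 4, `C#CCNC1CCc2c(SCCc3cccc(OC)c3)cccc21`, has not yet been measured. It keeps the two-carbon linker of compound 1 and changes only the substituent on the outer ring: methoxy in place of trifluoromethyl on an aromatic carbon. Among the compounds with values here, no two measured compounds differ by this one change, so the effect has to be estimated from the spread of the three values alone. A modest rise in the number is expected, that is slightly weaker inhibition, with the step from compound 1 to compound 4 estimated at a 2.0-fold higher number from compound 1 to compound 4 (0.29 log units; within the scatter). For compound 4 the expected value in this assay is 550 nM, within a range from 150 nM to 2000 nM.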

Compound 4, half-maximal inhibitory concentration: 3820 nM
Beside the measured number, compound 4's estimate is 6.9-fold (0.84 log units) below it; the whole stated range lies below it.
By their numbers in this assay, from the lowest: compound 3; then compound 1; then compound 2; then compound 4.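

In this assay, putting methoxy in place of trifluoromethyl on an aromatic carbon of the outer ring gives a 14-fold higher number from compound 1 to compound 4 (1.13 log units; beyond the scatter) and is a large step. The earlier compounds shown here differ from one another in more than one place, so none of their gaps could be pinned on a single group; this pair shows that the group on this carbon can, on its own, move the number strongly, and that on the side arm of compound 1 trifluoromethyl goes with much stronger inhibition than methoxy. The data shown include no measurement that says which difference between the two groups is responsible.

Going by these compounds, one pair gives only two points at this position, so it remains open where a chlorine, a methyl, a hydroxyl or an amine on the same carbon would fall relative to these two groups. On these data alone, it is also open whether the same exchange would have a similar effect on the different side arms of compound 2 and compound 3.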